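The compounds below may be only part of what the source reports. "The series", "measured", "known", "first", "only" and "open" are said of these compounds alone.

Compound 1 `COc1ccccc1-c1cc(O)c2cc(C)cnc2n1` and compound 2 `Cc1cnc2nc(-c3ccc(F)cc3)cc(O)c2c1` share a core and differ only in the group attached to it. In a functional assay on cells (Tumor Cell line, Homo sapiens) for cytotoxicity (on this read-out lower numbers stand for stronger inhibition of growth and higher numbers for weaker inhibition of growth), compound 1 gives 31600 nM, and compound 2 gives 26300 nM; these two numbers lie within the usual scatter of repeated measurements, so neither compound can be called the more potent. Compound 3 `COc1ccc(-c2cc(O)c3cc(C)cnc3n2)cc1` has not yet been measured. Compared with compound 2: methoxy in place of fluoro on an aromatic carbon. For the measured compounds named here, no step between measured compounds is available to lean on, so the expected step of a 1.1-fold lower number from compound 2 to compound 3 (0.02 log units; within the scatter) is small, most likely none beyond the scatter. Compound 3 is estimated to give 25000 nM, within a range from 8000 nM to 80000 nM.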

Compound 3, concentration for 50% growth inhibition: 6170 nM
Beside the measured number, compound 3's estimate is 4.1-fold (0.61 log units) above it; the measured number lies below the stated range.
By their numbers in this assay, from the lowest: compound 3; then compounds 2 and 1 (each within the scatter of the next).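

The aromatic carbon para to a large group turns out to matter in this assay and methoxy in place of fluoro there brings a 4.3-fold lower number from compound 2 to compound 3 (0.63 log units; beyond the scatter) as the first clear difference in this set. Compound 1 and compound 2 could not be told apart, so that earlier pair gave no sign that swapping one group could shift growth inhibition this much. No measurement shown explains the change. Going by these compounds, whether an amine or a longer chain such as ethoxy on this carbon would go further, or fall back toward compound 2, remains open.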